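The compounds below may be only part of what the source reports. "The series", "measured", "known", "first", "only" and "open" are said of these compounds alone.

The measured compounds in an ADME assay on Vero cells (Chlorocebus sabaeus) for cytotoxicity, read by sulforhodamine B assay, with a stated time of 72 h (on this read-out lower numbers stand for stronger inhibition and higher numbers for weaker inhibition), are three. Compound 1 `CN1Cc2ccc(OCc3cccnc3)cc2[C@@H](O)C1` gives > 50000 nM, which is a limit of the assay and not a number. Compound 2 `CN1Cc2ccc(OCCCn3ccnc3[N+](=O)[O-])cc2[C@@H](O)C1` gives > 50000 nM, again only a limit. Compound 3 `CN1CCc2cc(Oc3ccccc3)ccc2C1` gives > 100000 nM, once more a limit rather than a value.

Compound 3 therefore stands at the limit of > 100000 nM in this assay, at which 1 of the 3 values shown sits, whereas compound 1 and compound 2 sit at the limit of > 50000 nM in this assay, at which 2 of the 3 values shown sit. Going by the values given here, since none of the three has a numerical value, no step between measured compounds can be sized, and nothing is known about which of them inhibits the cells more strongly.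

The piece follows compound 3 to compound 4 `CN1CCc2cc(Oc3ccc(-c4ccccc4)cc3)ccc2C1`. The change is phenyl in place of hydrogen on an aromatic carbon. Among the compounds with values here, no measured step bears on a change of this kind. The expectation is a step of a number no higher from compound 3 to compound 4 (the limit leaves the size open) in this assay, that is, none beyond the scatter, given that compound 3 already sits at a limit with > 100000 nM. Compound 4 is accordingly estimated at 100000 nM, with a range from 30000 nM to 300000 nM, and a fresh limit rather than a number is the more likely outcome.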

Compound 4, half-maximal inhibitory concentration: 22300 nM
Compound 4: the middle estimate sits 4.5-fold (0.65 log units) above what was measured, outside the stated range (below it).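

In this assay, going by these compounds alone, phenyl in place of hydrogen on an aromatic carbon, para to a large group, gives an at least 4.4-fold lower number from compound 3 to compound 4 (0.65 log units; beyond the scatter), so this position on the six-membered aromatic ring of carbon only can change the read-out, which none of the earlier compounds could show. Compound 4 gives 22300 nM, the first number rather than a limit among the compounds shown, and so the first value against which later changes could be sized. Compound 3 remains a limit and not a number, which leaves the full size of the step unknown: the limit of > 100000 nM in this assay, at which 1 of the 4 values shown sits.

With a single change at this position, the compounds shown leave open whether phenyl itself matters or any group on that carbon would do the same. A methyl group, an amine or a carboxylic acid in the same place would begin to separate these possibilities.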